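Fluoropyridinyl isomers in the solubility series

This account rests on a few compounds, and the source may have more. Where it says the series, first, only, none or still open, it means among the compounds named here.

Compound 1 `Fc1ccc(-c2nc3cnc(Nc4ccccn4)cc3[nH]2)cc1F` is the parent of this set, with an unsubstituted pyridinyl amine on the shared core. In a physicochemical assay for solubility, using the shake flask method, in phosphate buffer, measured as kinetic solubility, with a stated time of 20 h, at pH 6.5 (on this read-out higher numbers stand for higher solubility and lower numbers for lower solubility), compound 1 gives < 5000 nM, which is a limit of the assay and not a number. Compound 2 `Fc1ccc(-c2nc3cnc(Nc4cc(C(F)(F)F)ccn4)cc3[nH]2)cc1F` carries a trifluoromethyl in place of hydrogen on an aromatic carbon, and in this assay compound 2 gives < 5000 nM, again a limit. Compound 3 `Fc1ccc(Nc2cc3[nH]c(-c4ccc(F)c(F)c4)nc3cn2)nc1` carries a fluoro in place of hydrogen on an aromatic carbon, and in this assay compound 3 gives < 5000 nM, also a limit. Consequently the step that the two limits leave unreadable from compound 1 to compound 2 and the step that the two limits leave unreadable from compound 1 to compound 3 cannot be sized, because the limit of < 5000 nM in this assay, at which 3 of the 3 values shown sit, is where every value so far sits.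

Compound 4 `Fc1ccnc(Nc2cc3[nH]c(-c4ccc(F)c(F)c4)nc3cn2)c1` differs from compound 3 by 4-fluoropyridin-2-yl in place of 5-fluoropyridin-2-yl on a nitrogen on an aromatic ring. Neither measured step bears readably on this change, so no direction beyond the scatter can be expected from the numbers shown. Compound 4 is therefore expected to sit at about 2000 nM, within 400 nM to 5000 nM. The step that the limit leaves unreadable from compound 3 to compound 4 is the estimated consequence.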

Compound 4, solubility: < 5000 nM
Compound 4: only a limit was reported; the forecaster's own chance of this, stated with the estimate: 85%; the middle value does not contradict the limit.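

No new step can be read from compound 4 to compound 1, compound 2 or compound 3, because all of these values are limits and not numbers: the limit of < 5000 nM in this assay, at which 4 of the 4 values shown sit.

Going by these compounds, how far the solubility of each compound lies under that limit, and whether compound 3 and compound 4 differ at all, stays open.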